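Removing the bromo group from compound 2

The source may hold more compounds than are shown below. What is called first, only, known or untested is meant among the compounds shown, and "the series" means these compounds.

Of the compounds shown here, two have been measured so far. In a functional assay on MIA PaCa-2 cells (Homo sapiens) for inhibition, read by MTT assay, with a stated time of 48 h, tested at 10 uM (a higher number here means more inhibition of growth at the concentration tested, a lower number less inhibition of growth), compound 1 (`Cc1cc(=O)c2c(O)cc(OCc3ccccc3)c([C@H]3CCN(C)C[C@H]3O)c2o1`) gives 14% and compound 2 (`Cc1oc2c([C@H]3CCN(C)C[C@H]3O)c(O)cc(O)c2c(=O)c1C(O)c1ccc(F)c(Br)c1`) gives 9% at the single concentration tested. These two values lie within the usual scatter of each other, so compound 2 stands level with compound 1, and both show little inhibition of growth.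

Compound 3 (`Cc1oc2c([C@H]3CCN(C)C[C@H]3O)c(O)cc(O)c2c(=O)c1C(O)c1ccc(F)cc1`) differs from compound 2 in one place: hydrogen in place of bromo on an aromatic carbon (hydrogen in place of bromo on an aromatic carbon, ortho to a fluoro group), which turns 3-bromo-4-fluorophenyl into 4-fluorophenyl. Among the compounds with values here, no measured pair isolates this change, and compounds 1 and 2 differ in more than one place, so the data give no direct size for it. With compound 2 at 9% and no measured response to the bromo group, no step beyond the scatter is expected in this assay in either direction. The estimated change is a number 3 percentage points higher from compound 2 to compound 3 (within the scatter) and stays within the scatter. The expected value for compound 3 is 12% with an estimated range from 2% to 25% in this read-out.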

Compound 3, percent growth inhibition at one concentration: 17%
Compound 3: the middle estimate sits 5 percentage points below what was measured; low and high end bracket the measured number.
By their numbers in this assay, from the lowest: compounds 2, 1 and 3 (each within the scatter of the next).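

In this assay the series now has its first comparison in one place, and it reads a number 8 percentage points higher from compound 2 to compound 3 (within the scatter). At this position, then, 3-bromo-4-fluorophenyl and 4-fluorophenyl cannot be told apart: taking the bromo group off this aromatic carbon, ortho to a fluoro group, removes one heavy atom without a step beyond the scatter, and both compounds show little inhibition of growth at the single concentration tested. Nothing available bears on why the read-out responds in this way.

Still open is whether any group on this aromatic carbon can move the read-out, since hydrogen is the only replacement for bromo shown here, and an amine, a carboxylic acid or a methoxy group in the same place could behave differently. The fluoro group and the hydroxy of the (4-fluorophenyl)(hydroxy)methyl group also have no comparison in one place, and the steps from compound 1 to compound 2 and to compound 3 cannot be read, as compound 1 differs from each in more than one place.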